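A few compounds are considered here, and "the series" means these few. Any claim that something is new, unique, unknown or untested is made for them only; others in the source may bear on it.

Working notes on the group on the sulfonyl sulfur, with the shared core held constant. Among the measured compounds shown here, in a physicochemical assay for solubility, in phosphate buffer, with a stated time of 24 h, at pH 7.4, tested at 100 uM (on this read-out lower numbers stand for lower solubility and higher numbers for higher solubility), compound 1 (`O=C(NCc1ccc(S(=O)(=O)C2CCCOC2)cc1)N1Cc2ccncc2C1`) gives 208000 nM and compound 2 (`O=C(NCc1ccc(S(=O)(=O)N2CCOCC2)cc1)N1Cc2ccncc2C1`) gives 59000 nM as the lower of the two numbers so far. Compound 2 therefore sits at the bottom of this small set. Next comes compound 3 (`O=C(NCc1ccc(S(=O)(=O)N2CCC[C@@H](O)C2)cc1)N1Cc2ccncc2C1`), and the change is 3-hydroxypiperidin-1-yl in place of morpholin-4-yl on a sulfonyl sulfur with 3-hydroxypiperidin-1-yl in place of morpholin-4-yl on a sulfonyl sulfur. For the measured compounds named here, only one measured step bears on this: a 3.5-fold lower number from compound 1 to compound 2 (0.55 log units; beyond the scatter) is a modest step at the same sulfonyl sulfur, with morpholin-4-yl at its lower end. Going by the values given here, one step gives a size but no firm direction, and no measured compound carries 3-hydroxypiperidin-1-yl. A somewhat smaller step is expected in this assay and an upward one is thought more likely than a downward one, so the estimated move is a 2.2-fold higher number from compound 2 to compound 3 (0.34 log units; beyond the scatter) with wide margins. For compound 3 the estimated value is 130000 nM within an expected range of 50000 nM to 300000 nM on this read-out.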

Compound 3, solubility: 216000 nM
Compound 3: middle estimate off by 1.7-fold (0.22 log units), on the low side; the range from low to high includes it.
By their numbers in this assay, from the lowest: compound 2; then compounds 1 and 3 (each within the scatter of the next).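

In this assay, a second measured step now bears on morpholin-4-yl at this position, a 3.7-fold higher number from compound 2 to compound 3 (0.56 log units; beyond the scatter) with 3-hydroxypiperidin-1-yl entering, so morpholin-4-yl stands at the lower end against both other groups on the sulfonyl sulfur and not against oxan-3-yl alone. The remaining pair gives a 1.0-fold higher number from compound 1 to compound 3 (0.02 log units; within the scatter) with 3-hydroxypiperidin-1-yl in place of oxan-3-yl, so these two groups cannot be ordered on this read-out, and the compounds shown split into morpholin-4-yl on one side and the two other groups together on the other. Nothing measured here accounts for that split.

The compounds shown leave open whether the step away from morpholin-4-yl goes with the hydroxy group, with the ring that carries it or with its defined stereocentre, a question that plain piperidin-1-yl and the mirror-image 3-hydroxypiperidin-1-yl would help to separate. Also open, from the compounds shown here alone, is how a ring bearing an amine or a carboxylic acid on the same sulfonyl sulfur would compare, and whether any of these steps carries over to a core other than the shared one.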